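Replacing 1H-pyrazol-1-yl with cyclopropyl in compound 2

The compounds below may be only part of what the source reports. "The series", "measured", "known", "first", "only" and "open" are said of these compounds alone.

Values so far in a physicochemical assay for lipophilicity, read by HPLC, measured as chromatographic lipophilicity, at pH 7.4 (a lower number here means a more polar compound, a higher number a more lipophilic compound), are these:
- compound 1 `COc1cccc(NC(=O)c2nnn(Cc3ccncc3)c2N)c1` gives 1.4
- compound 2 `COc1cccc(NC(=O)c2nnn(Cc3ccc(-n4cccn4)cc3)c2N)c1` gives 2.4

Compound 2 holds the higher of these two numbers, and its gap to compound 1 lies beyond the usual scatter of repeated measurements. For the measured compounds named here, no two measured compounds differ in one place only, so no measured step can serve as a direct guide for the next change.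

That change leads to compound 3 `COc1cccc(NC(=O)c2nnn(Cc3ccc(C4CC4)cc3)c2N)c1` which has cyclopropyl in place of 1H-pyrazol-1-yl on an aromatic carbon and keeps the rest of compound 2 unchanged. The group that leaves holds nitrogen, whereas the group that enters is made of carbon only. With compound 2 at 2.4 as the starting point, this swap leads to the expectation of a higher number. The estimated change is a number 0.50 log units higher from compound 2 to compound 3 (beyond the scatter) which would be a moderate upward step beyond the scatter. In this assay compound 3 is estimated at 2.9 with an expected range of 2.5 to 3.3 as the span for the measurement.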

Compound 3, distribution coefficient: 3.2
The estimate for compound 3 lay 0.30 log units below the measured number, and the stated range covers the measured number.
By their numbers in this assay, from the lowest: compound 1; then compound 2; then compound 3.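

In this assay, putting cyclopropyl in place of 1H-pyrazol-1-yl on an aromatic carbon, para to a large group, gives a number 0.80 log units higher from compound 2 to compound 3 (beyond the scatter) and so provides a reading of one group on this ring, which compounds 1 and 2 alone could not give. The wider exchange, 4-cyclopropylphenyl in place of pyridin-4-yl on the saturated chain carbon bound to an aromatic nitrogen, gives a number 1.80 log units higher from compound 1 to compound 3 (beyond the scatter) and shows that the whole group at this end of the molecule can shift the reading well beyond the scatter while the rest stays the same. Nothing available explains the size of either step.

Still open, from the compounds shown here alone, is how an amine or a carboxylic acid on the same aromatic carbon would read in this assay and, with compound 3 at 3.2 as the mark, whether a longer carbon chain there would give a higher or a lower number. Going by these compounds, with one exchange of this kind on one core, it also stays open whether cyclopropyl in place of 1H-pyrazol-1-yl would give a step of similar size in another setting.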